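The compounds below may be only part of what the source reports. "The series", "measured", "known", "first", "only" and "open" are said of these compounds alone.

Working notes on the series

The series shares one core; compound 1 `O=C(O)c1cccc([C@H]2C[C@@H](c3ccc(OCc4c(-c5c(Cl)cccc5Cl)noc4C4CC4)cc3Cl)C2)c1` carries a 3-carboxyphenyl group on a four-membered ring. In an assay on isolated protein for agonist activity at Bile acid receptor (Homo sapiens), read by FRET (a lower number here means a smaller maximal response, a higher number a larger maximal response), compound 1 gives 99%. Compound 2 `O=C(O)CNC(=O)c1ccc(C2CC2c2ccc(OCc3c(-c4c(Cl)cccc4Cl)noc3C3CC3)cc2Cl)cc1` gives 100% in this assay, and compound 3 `O=C(O)c1cncc(C2CC2c2ccc(OCc3c(-c4c(Cl)cccc4Cl)noc3C3CC3)cc2Cl)c1` gives 103%. The three numbers sit together: compound 1 lies within the usual scatter of compound 2 and within the usual scatter of compound 3, so no order among the three can be read from them, and all three reach the full response of the reference.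

Compound 4 `O=C(O)c1cccc([C@H]2C[C@](O)(c3ccc(OCc4c(-c5c(Cl)cccc5Cl)noc4C4CC4)cc3Cl)C2)c1` has not been measured. It differs from compound 1 as follows: hydroxy in place of hydrogen on a saturated ring carbon. Among the measured compounds shown here, no step between measured compounds bears on a change of this kind, so the expectation for compound 4 rests only on the tight cluster of the three measured numbers.

The step from compound 1 to compound 4 is expected to be a number 1 percentage points lower from compound 1 to compound 4 (within the scatter), that is, no change beyond the scatter in either direction. Compound 4 is estimated to give 98% in this assay, with an expected range from 82% to 110%.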

Compound 4, largest response reached (reported as efficacy), in percent of the reference or control that the assay uses: 100%
The estimate for compound 4 lay 2 percentage points below the measured number, within the range that was stated.
By their numbers in this assay, from the lowest: compounds 1, 2, 4 and 3 (each within the scatter of the next).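

In this assay, among the compounds shown here, hydroxy in place of hydrogen on a saturated ring carbon gives a number 1 percentage points higher from compound 1 to compound 4 (within the scatter) and this is the first step that isolates a change in one place. The earlier compounds shown here could not speak to this position, as no step among them was available; the new step shows that this carbon of the four-membered ring, two ring bonds from the ring atom that bears the 3-carboxyphenyl group, can carry a hydroxy group with no change in maximal response beyond the scatter. Nothing at hand bears on why the response stays level with this change.

On these data alone, whether the same carbon tolerates a different group, such as an amine or a methoxy group, remains open, and a single hydroxy step cannot show how far this tolerance extends. The maximal response also leaves open how much of compound 4 is needed to reach that response, compared with compound 1.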